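The source may hold more compounds than are shown below. What is called first, only, known or untested is meant among the compounds shown, and "the series" means these compounds.

Measured so far:
compound 1, `CCC(CC)/N=C(\NC#N)Nc1cccnc1`, 20 mg/kg
compound 2, `CCC(C)(CC)/N=C(\NC#N)Nc1cccnc1`, 0.5 mg/kg
compound 3, `CC(C)(C)/N=C(\NC#N)Nc1ccncc1`, 2.5 mg/kg

All three were tested in a functional assay on the whole organism (blood, strain Wistar-Okamoto) with Rattus norvegicus as the target, with a stated time of 5 days; a lower number here means that less compound is needed, a higher number that more compound is needed for the effect. Going by the values given here, compound 1 and compound 2 share one core, and the single change between them is methyl in place of hydrogen on a saturated chain carbon bound to a double-bonded nitrogen and two saturated chain carbons. That change gave a 40-fold lower number from compound 1 to compound 2 (1.60 log units; beyond the scatter), a large drop in the dose needed. Compound 3 has a different core; the difference between the two cores is not broken down here, and compound 3 sits between the other two with 2.5 mg/kg.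

Compound 4, `CCC(C)(C)/N=C(\NC#N)Nc1ccncc1`, has not yet been measured. It differs from compound 3 by methyl in place of hydrogen on a saturated chain carbon, two bonds along the chain from a double-bonded nitrogen. Among the compounds with values here, this is the same kind of change as the one from compound 1 to compound 2, but not the same: there the methyl entered on a saturated chain carbon bound to a double-bonded nitrogen and two saturated chain carbons, whereas here it enters on a saturated chain carbon two bonds along the chain from a double-bonded nitrogen, turning tert-butyl into 1,1-dimethylpropyl. Since the place differs, the large gain seen for compound 2 is not simply carried over. A modest improvement is expected for compound 4, estimated as a 2.5-fold lower number from compound 3 to compound 4 (0.40 log units; beyond the scatter), resting on the direction of the earlier step and the different place of the change. Compound 4 is therefore expected to give about 1 mg/kg, with a plausible range from 0.3 mg/kg to 4 mg/kg.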

Compound 4, minimum effective dose: 2.5 mg/kg
For compound 4 the middle estimate is 2.5-fold (0.40 log units) below the measured one; low and high end bracket the measured number.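

In this assay, adding the methyl to the tert-butyl group, which turns it into 1,1-dimethylpropyl, gave no change at the digits printed from compound 3 to compound 4 (within the scatter), so on this core the extra carbon did not alter the dose needed. A methyl in place of a hydrogen therefore did not bring the same result on both cores, and the large drop seen in the earlier pair did not carry over: the same change on two cores in this assay, a 40-fold lower number (1.60 log units; beyond the scatter) from compound 1 to compound 2 and no change at the digits printed (within the scatter) from compound 3 to compound 4, 40-fold (1.60 log units) apart, beyond the scatter of two such steps

This does not show why the two steps part ways, since they differ both in the core and in the place of the change: in the earlier pair the methyl enters on the saturated chain carbon bound to the double-bonded nitrogen, and here it enters two bonds along the chain from that nitrogen, and two pairs cannot separate these, nor do they give a rule for the whole series.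

The compounds shown leave open what the chain of compound 2 would do on the core of compound 4, which would test the core with the place of the change held the same. They also leave open whether a longer chain, or an amine or a hydroxyl group on the chain, would shift the dose needed on either core.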